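The source may hold more compounds than are shown below. What is called first, only, known or untested is meant among the compounds shown, and "the series" means these compounds.

In a functional assay on A549 cells (Homo sapiens) for inhibition, read by sulforhodamine B assay, with a stated time of 48 h (on this read-out higher numbers stand for weaker inhibition of growth and lower numbers for stronger inhibition of growth), compound 1 (`Cc1cc(=O)oc2cc(N=C=[Se])ccc12`) gives 3600 nM. Compound 2 (`CCOC(=[Se])Nc1ccc2c(C)cc(=O)oc2c1`) gives > 100000 nM, which is a limit and not a number. That places compound 2 at the limit of > 100000 nM in this assay, at which 1 of the 3 values shown sits. For compound 3 (`CCCCOC(=[Se])Nc1ccc2c(C)cc(=O)oc2c1`) the entry is "nd(insoluble)" (no result reported). Compound 4 (`CCCCNC(=[Se])Nc1ccc2c(C)cc(=O)oc2c1`) differs from compound 2 by butylamino in place of ethoxy on a saturated chain carbon bound to a nitrogen on an aromatic ring, with butylamino in place of ethoxy on a saturated chain carbon bound to a nitrogen on an aromatic ring. Going by the values given here, only one measured step bears on this change: an at least 27-fold higher number from compound 1 to compound 2 (1.44 log units; beyond the scatter), which is large and beyond the scatter. With that step as the guide, a move towards stronger inhibition in this assay is expected, estimated as an at least 3.3-fold lower number from compound 2 to compound 4 (0.52 log units; beyond the scatter). For compound 4 the estimated value is 30000 nM, with an expected range of 6000 nM to 100000 nM.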

Compound 4, concentration for 50% growth inhibition: 3000 nM
The estimate for compound 4 lay 10-fold (1.00 log units) above the measured number; the measured number lies below the stated range.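

In this assay, going by these compounds alone, butylamino in place of ethoxy on a saturated chain carbon bound to a nitrogen on an aromatic ring gives an at least 33-fold lower number from compound 2 to compound 4 (1.52 log units; beyond the scatter), the first measured step at this position and a large one. The value of compound 2 is a limit and not a number: the limit of > 100000 nM in this assay, at which 1 of the 4 values shown sits. Going by these compounds, the full size of the step therefore stays unknown.

The compounds shown do not separate the effect of the ring-free chain length from that of the nitrogen replacing oxygen, as compound 3 has no result. An ethylamino group would bear on this, and a longer chain would show whether the trend continues.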